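The source may hold more compounds than are shown below. What is called first, only, known or untested is meant among the compounds shown, and "the series" means these compounds.

Measured in a functional assay on HCT-116 cells (Homo sapiens) for antiproliferative activity, read by MTT assay, with a stated time of 72 h; a lower number here means a stronger inhibitor, a higher number a weaker inhibitor:
- Compound 1 `CC(C)NC(=N)NC(=N)Nc1ccc(C(F)(F)F)cc1`: 4800 nM
- Compound 2 `CC(C)NC(=N)NC(=N)Nc1ccc(F)c(F)c1`: > 50000 nM (a limit of the assay)
- Compound 3 `CCCCCCCNC(=N)NC(=N)Nc1ccc(F)c(F)c1`: 1800 nM

Compound 2 has no number of its own: its > 50000 nM in this assay is a limit of the assay. Compound 4 `CC(C)NC(=N)NC(=N)Nc1ccc(F)cc1` departs from it by a single change, (hydrogen in place of fluoro on an aromatic carbon), that is, hydrogen in place of fluoro on an aromatic carbon.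

Among the measured compounds shown here, the only measured step of one change is an at least 27-fold lower number from compound 2 to compound 3 (1.44 log units; beyond the scatter), which is large and comes from heptyl in place of isopropyl on an amine nitrogen. That change lies in the chain and not on the aromatic carbon, so it does not size the present change. Compound 1 keeps the isopropyl and gives 4800 nM, so a compound with this chain can yield a number in this assay. For the measured compounds named here, no measured step covers the removal of a fluoro group. Compound 4 also keeps the isopropyl of compound 2, whose > 50000 nM is a limit, so no step beyond the scatter is expected in this assay, and the assay may again report only a limit. The expected change is a number no higher from compound 2 to compound 4 (the limit leaves the size open). For compound 4 the estimated value is 50000 nM, with an expected range from 20000 nM to 100000 nM.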

Compound 4, half-maximal inhibitory concentration: > 50000 nM
Compound 4 gave a limit, no number (the forecaster's own chance of this, stated with the estimate: 65%); the middle value lies on the limit itself.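

Hydrogen in place of fluoro on the aromatic carbon still leaves this isopropyl compound without a number in this assay: compound 4 gives only a limit of the assay, > 50000 nM. The step from compound 2 to compound 4 cannot be read, as both ends are limits: the limit of > 50000 nM in this assay, at which 2 of the 4 values shown sit. The one readable step is an at least 10-fold higher number from compound 1 to compound 4 (1.01 log units; beyond the scatter), with the isopropyl chain unchanged, so among these three isopropyl compounds only the one with trifluoromethyl gives a number, while those with one or two fluoro groups do not.

From the compounds shown here alone, what the second fluoro group contributes stays open, since neither compound with the isopropyl chain and fluoro on the ring gives a number to compare. Going by these compounds, it also remains open whether a heptyl chain would bring a number to the core of compound 4, and whether a chloro or nitrile group in place of trifluoromethyl would give a number with the isopropyl chain.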